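This account rests on a few compounds, and the source may have more. Where it says the series, first, only, none or still open, it means among the compounds named here.

Measured in an ADME assay on MT4 cells (Homo sapiens) for cytotoxicity, read by MTT assay; a higher number here means that more compound is tolerated, a lower number that less compound is tolerated:
- compound 1 `O=C(CSc1nncnc1-c1cccc2ccccc12)Nc1ccccc1[N+](=O)[O-]`: 142000 nM
- compound 2 `CC(=O)c1ccc(NC(=O)CSc2nncnc2-c2cccc3ccccc23)c(Br)c1`: 133000 nM
- compound 3 `O=C(CSc1nncnc1-c1cccc2ccccc12)Nc1ccccc1`: 154000 nM

At 154000 nM, compound 3 cannot be told apart from the other two compounds in this assay. The data show a 1.1-fold higher number from compound 1 to compound 3 (0.04 log units; within the scatter) and a 1.2-fold higher number from compound 2 to compound 3 (0.06 log units; within the scatter), and both steps lie within the scatter.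

The next compound is compound 4 `Cc1ccc(NC(=O)CSc2nncnc2-c2cccc3ccccc23)c([N+](=O)[O-])c1`, which puts 4-methyl-2-nitrophenyl in place of phenyl on the amide-type nitrogen: 4-methyl-2-nitrophenyl in place of phenyl on an amide-type nitrogen.

For the measured compounds named here, two measured steps bear on this change. The nitro group alone accounts for a 1.1-fold higher number from compound 1 to compound 3 (0.04 log units; within the scatter), where hydrogen replaces nitro on an aromatic carbon. A different substituted phenyl on the same nitrogen gives a 1.2-fold higher number from compound 2 to compound 3 (0.06 log units; within the scatter). Going by the values given here, no measured compound tests the methyl group alone, so that part of the change remains open. With both steps inside the scatter, no shift beyond the scatter is expected in this assay.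

The expected step is a 1.1-fold lower number from compound 3 to compound 4 (0.04 log units; within the scatter).

For compound 4 the estimated value is 140000 nM, with an expected range from 85000 nM to 230000 nM.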

Compound 4, half-maximal cytotoxic concentration: 147000 nM
Beside the measured number, compound 4's estimate is 1.1-fold (0.02 log units) below it, within the range that was stated.
By their numbers in this assay, from the lowest: compounds 2, 1, 4 and 3 (each within the scatter of the next).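

In this assay, the methyl group can now be read on its own: methyl in place of hydrogen on an aromatic carbon gives a small step (a 1.0-fold higher number from compound 1 to compound 4 (0.02 log units; within the scatter)). The full change to 4-methyl-2-nitrophenyl on the amide-type nitrogen behaves the same way, both from phenyl (a 1.0-fold lower number from compound 3 to compound 4 (0.02 log units; within the scatter)) and from 4-acetyl-2-bromophenyl (a 1.1-fold higher number from compound 2 to compound 4 (0.04 log units; within the scatter)), so the four aryl groups shown on this nitrogen all lie within the scatter of one another in these steps. Nothing else measured here bears on this result.

Going by these compounds, whether a carboxylic acid or an amine on the phenyl ring, or a saturated alkyl chain in place of the ring on this nitrogen, would shift the number remains open. On these data alone, the shared core is the same in all four compounds, so the effect of changing it is also open.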